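Vero Cell Tolerance After a Chloro-to-Methoxy Swap

The source may report more compounds than this note shows. Statements on the series, on what has been measured and on what is new or still open speak of the compounds shown alone.

Compound 2 `NS(=O)(=O)c1ccc(N2N=C(c3ccc(Cl)cc3)CC2c2cn(-c3ccccc3)nc2-c2ccc(Cl)cc2)cc1` has been tested in an ADME assay on Vero cells (Chlorocebus sabaeus) for cytotoxicity, read by MTT assay, with a stated time of 72 h; a lower number here means that less compound is tolerated, a higher number that more compound is tolerated. In this assay compound 2 gives only a limit, > 164000 nM, and not a measured number. Compound 1 `COc1ccc(C2=NN(c3ccc(S(N)(=O)=O)cc3)C(c3cn(-c4ccccc4)nc3-c3ccc(F)cc3)C2)cc1` likewise reaches only a limit in this assay, > 53100 nM. Compound 2 thus sits at the limit described by the limit of > 164000 nM in this assay, at which 1 of the 2 values shown sits. Compound 3 `COc1ccc(C2=NN(c3ccc(S(N)(=O)=O)cc3)C(c3cn(-c4ccccc4)nc3-c3ccc(Cl)cc3)C2)cc1` carries methoxy in place of chloro on an aromatic carbon. For the measured compounds named here, no step between measured compounds is available here. The step from compound 2 to compound 3 is expected to stay within the usual scatter, an at least 1.6-fold lower number from compound 2 to compound 3 (0.21 log units; that floor lies within the scatter). Compound 3 is expected to give 100000 nM, in the range from 50000 nM to 200000 nM, most likely again as a limit.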

Compound 3, half-maximal cytotoxic concentration: 31300 nM
The estimate for compound 3 lay 3.2-fold (0.50 log units) above the measured number, outside the stated range (below it).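

For the compounds shown here, compound 3 is the first compound here to give a real number in this assay, and methoxy in place of chloro brings a clear change: an at least 5.2-fold lower number from compound 2 to compound 3 (0.71 log units; beyond the scatter). That size is only a floor, because compound 2 stops at a limit: the limit of > 164000 nM in this assay, at which 1 of the 3 values shown sits.

Chloro in place of fluoro gives an at least 1.6-fold lower number from compound 1 to compound 3 (0.22 log units; that floor lies within the scatter), and this floor cannot settle whether that change matters, because compound 1 also stops at a limit: the limit of > 53100 nM in this assay, at which 1 of the 3 values shown sits.

The compounds shown leave open whether the fall belongs to methoxy itself or would come with other groups at this place, such as an amine or a carboxylic acid.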